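The source may hold more compounds than are shown below. What is called first, only, known or untested is meant among the compounds shown, and "the series" means these compounds.

For the measured compounds named here, only two compounds have numbers so far in an ADME assay on Vero cells (Chlorocebus sabaeus) for cytotoxicity; on this read-out lower numbers stand for higher toxicity in this test and higher numbers for lower toxicity in this test. In this test compound 1 `CCO/N=C1/C(=O)N(Cc2cn(CC(=O)N3CCN(c4cc5c(cc4F)c(=O)c(C(=O)O)cn5C4CC4)CC3)nn2)c2ccc(C)cc21` gives 32 ug/mL, and compound 2 `CO/N=C1/C(=O)N(Cc2cn(CC(=O)N3CCN(c4cc5c(cc4F)c(=O)c(C(=O)O)cn5C4CC4)CC3)nn2)c2ccc(C)cc21` gives 8 ug/mL. Compound 2 therefore holds the lower of the two numbers, which here stands for the higher toxicity in this test.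

Compound 3 `CO/N=C1/C(=O)N(Cc2cn(CC(=O)N3CCN(c4cc5c(cc4F)c(=O)c(C(=O)O)cn5C4CC4)CC3)nn2)c2ccc(F)cc21` keeps the structure of compound 2 except for one group: fluoro in place of methyl on an aromatic carbon.

Going by the values given here, only one measured step exists, and it bears on this change only indirectly. That step, a 4.0-fold lower number from compound 1 to compound 2 (0.60 log units; beyond the scatter), is modest but beyond the scatter. It comes from a different edit elsewhere in the molecule: hydrogen in place of methyl on a saturated chain carbon bound to an oxygen on an unsaturated carbon. Among the compounds with values here, it shows that a single small edit can move this number, but no measured pair shows fluoro replacing methyl.

With no direct evidence, the expected change is none beyond the scatter, an estimated 1.3-fold higher number from compound 2 to compound 3 (0.10 log units; within the scatter). For compound 3 the estimated value is 10 ug/mL, with an expected range from 4 ug/mL to 32 ug/mL.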

Compound 3, half-maximal cytotoxic concentration: 64 ug/mL
The estimate for compound 3 lay 6.4-fold (0.81 log units) below the measured number, and the stated range ends below it.
By their numbers in this assay, from the lowest: compound 2; then compounds 1 and 3 (each within the scatter of the next).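

In this assay, putting fluoro in place of methyl on this aromatic carbon gives an 8.0-fold higher number from compound 2 to compound 3 (0.90 log units; beyond the scatter) and so moves the number towards lower toxicity in this test. For the compounds shown here, this is the first measured sign that the position on the six-membered aromatic ring responds to a change of a single heavy atom, since the only earlier step, a 4.0-fold lower number from compound 1 to compound 2 (0.60 log units; beyond the scatter), came from an edit on the chain bound to oxygen, elsewhere in the molecule, and went the other way. Nothing measured in this set of compounds explains why this swap raises the number.

With only methyl and fluoro shown on this carbon, the compounds leave open how the number would respond to other groups there, such as chloro, methoxy or an amine, or to plain hydrogen, which would show whether fluoro raises the number or methyl lowers it. They also leave open whether the swap from methyl to fluoro would move the number in the same direction when the shorter oxygen-bound chain of compound 2 is replaced by the longer one of compound 1.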